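A Methoxyphenyl Swap on Compound 2

The compounds below may be only part of what the source reports. "The series", "measured", "known", "first", "only" and "open" are said of these compounds alone.

In an ADME assay on microsomes from liver (Rattus norvegicus) for metabolic stability, read by LC-MS, in the presence of a further agent that is not named here (on this read-out higher numbers stand for fast clearance and lower numbers for slow clearance), compound 1 `COc1cccnc1-c1nc2ccc(-c3nc4c(C)ncc(C)n4n3)cc2[nH]1` gives 5.4 mL.min-1.g-1 and compound 2 `Cc1ncc(C)n2nc(-c3ccn4cc(-c5ccc(F)cc5Cl)nc4n3)nc12` gives 11.5 mL.min-1.g-1 as the higher of the two numbers, a gap beyond the usual scatter. Compound 3 `COc1ccccc1-c1cn2ccc(-c3nc4c(C)ncc(C)n4n3)nc2n1` has no number yet. It carries 2-methoxyphenyl in place of 2-chloro-4-fluorophenyl on an aromatic carbon and otherwise matches compound 2. Going by the values given here, no two measured compounds differ in one place, so no measured step guides this change. Among the compounds with values here, the only hint is compound 1 at 5.4 mL.min-1.g-1 with a methoxy group on its own aromatic ring, but its core differs. In this assay only a small fall is therefore expected, one that stays within the scatter. The estimate amounts to a 1.2-fold lower number from compound 2 to compound 3 (0.06 log units; within the scatter) and no more. Compound 3 is expected at 10 mL.min-1.g-1 (range 5 mL.min-1.g-1 to 21 mL.min-1.g-1).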

Compound 3, intrinsic clearance in microsomes: 9.1 mL.min-1.g-1
The estimate for compound 3 lay 1.1-fold (0.04 log units) above the measured number; low and high end bracket the measured number.
By their numbers in this assay, from the lowest: compounds 1, 3 and 2 (each within the scatter of the next, the first and the last beyond it).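

In this assay, going by these compounds alone, this is the first step that can be read at this aromatic carbon of the five-membered ring, and it comes to a 1.3-fold lower number from compound 2 to compound 3 (0.10 log units; within the scatter). On the shared core, 2-methoxyphenyl and 2-chloro-4-fluorophenyl therefore cannot be told apart on this read-out, even though the exchange replaces both halogens with a methoxy group and brings in a hydrogen-bond acceptor. No measurement at hand offers an explanation for this result.

The compounds shown leave open whether the chlorine, the fluorine or the methoxy group matters on its own, since all of them change together in this single step. They also leave open whether an amine or a carboxylic acid on this phenyl ring would move the clearance beyond the scatter.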